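Adding a tert-Butoxycarbonyloxy Group to a Thiazolidinedione Core

The compounds below may be only part of what the source reports. "The series", "measured", "known", "first", "only" and "open" are said of these compounds alone.

Compound 1 `Cc1cc(C)c2c(c1C)OC(C)(COc1ccc(CC3SC(=O)NC3=O)cc1)CC2`: 12300 nM
Compound 2 `Cc1c(C)c2c(c(C)c1OC(=O)CCCC[C@@H]1SC[C@@H]3NC(=O)N[C@@H]31)CCC(C)(COc1ccc(/C=C3\SC(=O)NC3=O)cc1)O2`: 3500 nM
Compound 3 `Cc1c(C)c2c(c(C)c1OC(=O)CCCCCCCNC(=O)CCCC[C@@H]1SC[C@@H]3NC(=O)N[C@@H]31)CCC(C)(COc1ccc(/C=C3\SC(=O)NC3=O)cc1)O2`: 3700 nM

These three compounds were tested in a functional assay on MDA-MB-231 cells (Homo sapiens) for antiproliferative activity, read by luminescence, with a stated time of 24 h; on this read-out lower numbers stand for stronger inhibition and higher numbers for weaker inhibition. Compound 1 gives the highest number of the three and is therefore the weakest inhibitor here; both compound 3 and compound 2 sit below it by more than the usual scatter. Compound 4 `Cc1c(C)c2c(c(C)c1OC(=O)OC(C)(C)C)CCC(C)(COc1ccc(CC3SC(=O)NC3=O)cc1)O2` differs from compound 1 by one change: (tert-butoxycarbonyl)oxy in place of hydrogen on an aromatic carbon. Going by the values given here, no measured pair isolates this change, so the direction can only be guessed from compound 2 and compound 3, whose lower numbers come with a group in the place that is hydrogen in compound 1, but also with other differences. A modest step downward is expected, a 1.8-fold lower number from compound 1 to compound 4 (0.24 log units; within the scatter) in this assay. Compound 4 is estimated at 7000 nM, with a range from 2500 nM to 20000 nM.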

Compound 4, half-maximal inhibitory concentration: 3800 nM
For compound 4 the middle estimate is 1.8-fold (0.27 log units) above the measured one, within the range that was stated.
By their numbers in this assay, from the lowest: compounds 2, 3 and 4 (each within the scatter of the next); then compound 1.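

In this assay, (tert-butoxycarbonyl)oxy in place of hydrogen on this aromatic carbon gives a 3.2-fold lower number from compound 1 to compound 4 (0.51 log units; beyond the scatter). Going by these compounds alone, this is the first pair differing in one place only, so the step can be tied to this single change, and it lies beyond the scatter. The carbon, ortho to two methyl groups, can therefore carry a group of 8 heavy atoms without the number rising.

As far as these compounds go, whether a smaller group here, such as hydroxy or acetoxy, would give a similar step remains open. No measurement shown gives a reason for the step.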